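Swapping Isopropyl for Iodo in a Sulfonate Ester Series

A few compounds are considered here, and "the series" means these few. Any claim that something is new, unique, unknown or untested is made for them only; others in the source may bear on it.

Measured compounds:
Compound 1 `CC(C)c1ccccc1OS(=O)(=O)c1ccc(NC(=O)C(C)(C)C)cc1` gives 11000 nM
Compound 2 `CC(C)(C)C(=O)Nc1ccc(S(=O)(=O)Oc2ccccc2I)cc1` gives 2600 nM
Compound 3 `CC(C)c1ccccc1OS(=O)(=O)c1ccc(NC(=O)CCCCl)cc1` gives 3800 nM

These numbers come from a functional assay on HT-1080 cells (Homo sapiens) for antiproliferative activity, read by sulforhodamine B assay, with a stated time of 48 h; a higher number here means a weaker inhibitor, a lower number a stronger inhibitor. Compound 4 `O=C(CCCCl)Nc1ccc(S(=O)(=O)Oc2ccccc2I)cc1` has not yet been measured in this assay. It differs from compound 3 in one place: iodo in place of isopropyl on an aromatic carbon. The same change separates compound 1 from compound 2, (iodo in place of isopropyl on an aromatic carbon), and there it made a 4.2-fold lower number from compound 1 to compound 2 (0.63 log units; beyond the scatter). The two cores differ from each other by 3-chloropropyl in place of tert-butyl on a carbonyl carbon, a change that gave a 2.9-fold lower number from compound 1 to compound 3 (0.46 log units; beyond the scatter). The earlier iodo step lies beyond the scatter, and the expectation for compound 4 rests on it. A step of similar size is expected, namely a 3.8-fold lower number from compound 3 to compound 4 (0.58 log units; beyond the scatter). Compound 4 is therefore estimated at 1000 nM in this assay, with a likely range from 400 nM to 2500 nM.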

Compound 4, half-maximal inhibitory concentration: 12000 nM
For compound 4 the middle estimate is 12-fold (1.08 log units) below the measured one; measured number above the stated range.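

On the core of compound 3, iodo in place of isopropyl gave a 3.2-fold higher number from compound 3 to compound 4 (0.50 log units; beyond the scatter) in this assay, so the step seen on the core of compound 1 did not carry over: the same change on two cores in this assay, a 4.2-fold lower number (0.63 log units; beyond the scatter) from compound 1 to compound 2 and a 3.2-fold higher number (0.50 log units; beyond the scatter) from compound 3 to compound 4, 13-fold (1.13 log units) apart, beyond the scatter of two such steps

The chain change also depended on its setting, with 3-chloropropyl in place of tert-butyl giving a 4.6-fold higher number from compound 2 to compound 4 (0.66 log units; beyond the scatter): the same change on two cores in this assay, a 2.9-fold lower number (0.46 log units; beyond the scatter) from compound 1 to compound 3 and a 4.6-fold higher number (0.66 log units; beyond the scatter) from compound 2 to compound 4, 13-fold (1.13 log units) apart, beyond the scatter of two such steps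

These four compounds therefore show that the two changes do not act independently here, but they do not show why, or which core's result would be more typical.

On these data alone, it remains open whether the reversal is specific to the pairing of iodo with 3-chloropropyl. A bromo group on the aromatic ring, or a longer chain on the carbonyl, could help to settle this.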